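Trifluoromethyl to Tert-Butyl on a Shared Core

This account rests on a few compounds, and the source may have more. Where it says the series, first, only, none or still open, it means among the compounds named here.

Of the compounds shown here, two on a shared core have been measured in an assay on isolated protein with metabotropic glutamate receptor 1 (Homo sapiens) as the target; a lower number here means that less compound is needed, a higher number that more compound is needed for the effect. Compound 1 `CN(C)Cc1cn(CC(=O)Nc2sc3c(c2C(N)=O)CCCC3)nc1C(C)(C)C` gives 316 nM. Compound 2 `CC(C)NCc1cn(CC(=O)Nc2sc3c(c2C(N)=O)CCCC3)nc1C(F)(F)F` gives 3160 nM, the higher of the two numbers, and the gap from compound 1 up to compound 2 lies beyond the scatter. Within the data shown here, the two differ in two places at once, so no single step between them can be read off.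

Compound 3 `CC(C)NCc1cn(CC(=O)Nc2sc3c(c2C(N)=O)CCCC3)nc1C(C)(C)C` is compound 2 with one change: tert-butyl in place of trifluoromethyl on an aromatic carbon. Compound 3 therefore joins the tert-butyl of compound 1 to the (isopropylamino)methyl group of compound 2.

Because compound 1 with the same tert-butyl gives 316 nM while compound 2 gives 3160 nM, the step in this assay from compound 2 to compound 3 is expected to run downward by a 3.5-fold lower number from compound 2 to compound 3 (0.55 log units; beyond the scatter), though how much of the gap belongs to the tert-butyl and how much to the amine cannot be told from two compounds. Compound 3 is accordingly estimated at 900 nM, within a range from 250 nM to 3200 nM.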

Compound 3, half-maximal effective concentration: 1580 nM
For compound 3 the middle estimate is 1.8-fold (0.24 log units) below the measured one, within the range that was stated.
By their numbers in this assay, from the lowest: compound 1; then compounds 3 and 2 (each within the scatter of the next).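

In this assay, tert-butyl in place of trifluoromethyl on this aromatic carbon, next to the ring nitrogen, gives a 2.0-fold lower number from compound 2 to compound 3 (0.30 log units; within the scatter), so with the (isopropylamino)methyl group present the two groups cannot be told apart at this position. The other single change now has its own step: isopropylamino in place of dimethylamino on the saturated chain carbon, with tert-butyl held constant, gives a 5.0-fold higher number from compound 1 to compound 3 (0.70 log units; beyond the scatter). Of the two single changes, only this one lies beyond the scatter, which the earlier pair of compounds, differing in two places at once, could not show, and nothing at hand explains either step.

The compounds shown leave open whether trifluoromethyl and tert-butyl would also read alike with dimethylamino on the chain, since only the tert-butyl member of that pair appears here. They also leave open how a methyl or cyclopropyl group would read on this aromatic carbon, and how a primary amine or a morpholine would read in place of the isopropylamino group.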